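Ester to ether swap on the side-chain oxygen

The compounds below may be only part of what the source reports. "The series", "measured", "known", "first", "only" and "open" are said of these compounds alone.

Compound 1 `CC(C)=CC[C@@H](OC(=O)c1ccoc1)C1=CC(=O)c2c(O)ccc(O)c2C1=O`: in a functional assay on HeLa cells (Homo sapiens) for cytotoxicity, read by MTT assay (a lower number here means a stronger inhibitor, a higher number a weaker inhibitor), compound 1 gives > 100000 nM, a limit of the assay.
Compound 2 `CC(C)=CC[C@@H](OC(=O)CCO)C1=CC(=O)c2c(O)ccc(O)c2C1=O`: compound 2 gives 67600 nM.
Compound 3 `CCC(O)(CC)CC(=O)O[C@H](CC=C(C)C)C1=CC(=O)c2c(O)ccc(O)c2C1=O`: compound 3 gives 52000 nM.

Compound 3 and compound 2 sit within the scatter of each other, a 1.3-fold lower number from compound 2 to compound 3 (0.11 log units; within the scatter), so neither can be placed above the other. The steps of an at least 1.4-fold lower number from compound 1 to compound 2 (0.17 log units; that floor lies within the scatter) and an at least 1.9-fold lower number from compound 1 to compound 3 (0.28 log units; that floor lies within the scatter) start from the limit of > 100000 nM in this assay, at which 1 of the 3 values shown sits, and give only floors. Compound 4 `CC(=O)OC(C)CO[C@H](CC=C(C)C)C1=CC(=O)c2c(O)ccc(O)c2C1=O` differs from compound 3 by 2-acetoxypropyl in place of (2-ethyl-2-hydroxybutyl)carbonyl on an oxygen on a saturated carbon. Going by the values given here, none of the measured steps touches this oxygen in the same way; all three vary the carbonyl-bearing group only, and none rises beyond the scatter. No step beyond the scatter is therefore expected, a 1.0-fold lower number from compound 3 to compound 4 (0.02 log units; within the scatter). Compound 4 is expected to give 50000 nM, between 20000 nM and 130000 nM.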

Compound 4, half-maximal inhibitory concentration: 40100 nM
Beside the measured number, compound 4's estimate is 1.2-fold (0.10 log units) above it; the measured number falls inside the stated range.
By their numbers in this assay, from the lowest: compounds 4, 3 and 2 (each within the scatter of the next). At a limit, above all of these: compound 1.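

With 2-acetoxypropyl on the oxygen on a saturated carbon, an ether takes the place of the esters with no change beyond the scatter in this assay, the two steps being a 1.3-fold lower number from compound 3 to compound 4 (0.11 log units; within the scatter) and a 1.7-fold lower number from compound 2 to compound 4 (0.23 log units; within the scatter) as printed. A carbonyl on this oxygen is therefore not required for a number in this range. Going by these compounds alone, only the step of an at least 2.4-fold lower number from compound 1 to compound 4 (0.39 log units; beyond the scatter) lies beyond the scatter, and it is a floor, because compound 1 stands at a limit: the limit of > 100000 nM in this assay, at which 1 of the 4 values shown sits.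

As far as these compounds go, whether an ether on this oxygen carrying an amine, a carboxylic acid or a longer chain would move the number beyond the scatter stays open.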